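From 2-aminoethyl to benzyl on a shared core

The compounds below may be only part of what the source reports. "The series", "measured", "known", "first", "only" and "open" are said of these compounds alone.

In a functional assay on MDA-MB-435 cells (Homo sapiens) for cytotoxicity, read by MTT assay, with a stated time of 72 h (on this read-out lower numbers stand for stronger inhibition and higher numbers for weaker inhibition), compound 1 (`CN(C)CCCNc1c(C(=O)NCc2ccc(F)cc2)nc(Br)c2cccnc12`) gives 7000 nM while compound 2 (`N[C@H]1CC[C@H](Nc2c(C(=O)NCc3ccc(F)cc3)nc(Br)c3cccnc23)CC1`) gives 6000 nM and compound 3 (`NCCNc1c(C(=O)NCc2ccc(F)cc2)nc(Br)c2cccnc12`) gives 12000 nM on the same read-out. Compound 3 thus sits level with the other two, within the usual scatter of both. Compound 4 (`O=C(NCc1ccc(F)cc1)c1nc(Br)c2cccnc2c1NCc1ccccc1`) differs from compound 3 in one place, with phenyl in place of aminomethyl on a saturated chain carbon bound to a nitrogen on an aromatic ring. Three measured changes in this same side chain bear on it. They are a 1.2-fold lower number from compound 1 to compound 2 (0.07 log units; within the scatter) and a 1.7-fold higher number from compound 1 to compound 3 (0.23 log units; within the scatter) and a 2.0-fold higher number from compound 2 to compound 3 (0.30 log units; within the scatter) and each stayed within the scatter. For the measured compounds named here, no measured compound carries phenyl at this place, so the data offer no direction for the new change. A step beyond the scatter is therefore not expected, and the estimated step is a 1.3-fold lower number from compound 3 to compound 4 (0.12 log units; within the scatter) in this assay as a working figure only. For compound 4 the value is estimated at 9000 nM (expected range 3000 nM to 30000 nM).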

Compound 4, half-maximal inhibitory concentration: > 20000 nM
Compound 4 gave a limit, no number; the forecaster's own chance of this, stated with the estimate: 10%; middle value at least 2.2-fold (0.34 log units) from the limit.
By their numbers in this assay, from the lowest: compounds 2, 1 and 3 (each within the scatter of the next). At a limit, above all of these: compound 4.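

In this assay, compound 4 gives a limit and not a number: the limit of > 20000 nM in this assay, at which 1 of the 4 values shown sits. For the compounds shown here, the three side chains that carry an amine stayed within the scatter of one another, and benzyl is the first group here to part clearly from any of them, with an at least 3.3-fold higher number from compound 2 to compound 4 (0.52 log units; beyond the scatter) and with an at least 2.8-fold higher number from compound 1 to compound 4 (0.45 log units; beyond the scatter). Against its closest relative the result is less sharp, since an at least 1.6-fold higher number from compound 3 to compound 4 (0.22 log units; that floor lies within the scatter) gives only a floor, and the true size of this step stays unknown.

The compounds shown do not separate the loss of the amine from the arrival of the aromatic ring. A plain cyclohexyl group would have a ring and no amine, while a benzyl group bearing an aminomethyl substituent would have both, and these two could tell the effects apart.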